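Moving the Ring Attachment on the Ether of Compound 2

This account rests on a few compounds, and the source may have more. Where it says the series, first, only, none or still open, it means among the compounds named here.

Of the compounds shown here, two built on a shared core have so far been measured in a functional assay on CHO cells for positive allosteric modulation of metabotropic glutamate receptor 2 (Homo sapiens), read by scintillation counting and GTPgammaS binding, with a stated time of 30 min; on this read-out higher numbers stand for larger maximal responses and lower numbers for smaller maximal responses. Compound 1 `CC(C)CCn1ccc(-c2ccc(Oc3ccccn3)cc2)c(C#N)c1=O` gives 249% in this assay. Within the data shown here, compound 2 `Cc1cc(Oc2ccc(-c3ccn(CCC(C)C)c(=O)c3C#N)cc2)ccn1` gives 266% in this assay, which makes compound 2 the highest of the two numbers; its nearest neighbour is compound 1, and the only measured step is a number 17 percentage points higher from compound 1 to compound 2 (beyond the scatter).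

Compound 3 `Cc1ncccc1Oc1ccc(-c2ccn(CCC(C)C)c(=O)c2C#N)cc1` has not been measured. Compared with compound 2, it carries 2-methylpyridin-3-yl in place of 2-methylpyridin-4-yl on an oxygen on an aromatic ring. Among the measured compounds shown here, the one measured step bears on this change only loosely: it exchanged one ring for another on the same oxygen, whereas the change to compound 3 keeps the same atoms and joins them differently. For the measured compounds named here, no step of exactly this kind has been measured. Going by the values given here, since the one available step was modest, a step of modest size in either direction, or none beyond the scatter, is expected for compound 3 in this assay. Compound 3 is therefore estimated at 250%, with a range from 200% to 300%, which amounts to an expected step of a number 16 percentage points lower from compound 2 to compound 3 (beyond the scatter).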

Compound 3, largest response reached (Emax), in percent of the reference or control that the assay uses: 256%
Beside the measured number, compound 3's estimate is 6 percentage points below it, within the range that was stated.
By their numbers in this assay, from the lowest: compounds 1, 3 and 2 (each within the scatter of the next, the first and the last beyond it).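

Changing the way the methylpyridine ring is joined to the oxygen on an aromatic ring, from 2-methylpyridin-4-yl to 2-methylpyridin-3-yl, leaves the maximal response in this assay within the scatter (a number 10 percentage points lower from compound 2 to compound 3 (within the scatter)), so on this read-out the position accepts a change of ring attachment with the atoms kept, something the earlier ring exchange could not show. Compound 3 also lies within the scatter of compound 1 (a number 7 percentage points higher from compound 1 to compound 3 (within the scatter)), so the step from compound 1 to compound 2, the only one of the three printed as beyond the scatter, is not repeated by the other methylpyridine, and the set gives no general rule that a methylpyridine on this oxygen outperforms pyridin-2-yl. No evidence at hand accounts for these results.

The compounds shown leave open whether the methyl group contributes anything on its own, which an unsubstituted pyridin-3-yl or pyridin-4-yl ring would address, and whether a longer chain such as ethyl, an amine or a carboxylic acid would be accepted in its place. They also leave open how far the response holds when the ring on the oxygen is a plain phenyl ring without its nitrogen.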